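From Methyl to Methylsulfanyl on the Shared Core

The compounds below may be only part of what the source reports. "The series", "measured", "known", "first", "only" and "open" are said of these compounds alone.

Among the compounds with values here, compound 1 `C#Cc1cn([C@@H]2O[C@H](CO)[C@@H](O)[C@H]2O)c2ncnc(C)c12` is the only member of this small set with a numerical result: in a functional assay on K562 cells (Homo sapiens), read by MTT assay, with a stated time of 72 h (on this read-out higher numbers stand for weaker inhibition and lower numbers for stronger inhibition), compound 1 gives 6920 nM. Compound 2 `Cc1ncnc2c1c(-c1ccoc1)cn2[C@@H]1O[C@H](CO)[C@@H](O)[C@H]1O` reaches only a limit of the assay, > 20000 nM. Compound 3 `Cc1ncnc2c1c(-c1cccs1)cn2[C@@H]1O[C@H](CO)[C@@H](O)[C@H]1O` likewise stops at a limit, > 20000 nM. The two measured steps both replace the ethynyl group: an at least 2.8-fold higher number from compound 1 to compound 2 (0.46 log units; beyond the scatter) and an at least 2.8-fold higher number from compound 1 to compound 3 (0.46 log units; beyond the scatter), while a step that the two limits leave unreadable from compound 2 to compound 3. Both of these rest on (the limit of > 20000 nM in this assay, at which 2 of the 3 values shown sit).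

Compound 4 `C#Cc1cn([C@@H]2O[C@H](CO)[C@@H](O)[C@H]2O)c2ncnc(SC)c12` changes a different part of the core than any measured step: methylsulfanyl in place of methyl on an aromatic carbon. Within the data shown here, no measured pair alters that carbon, so the ethynyl series offers no direct guide to its size or direction; it shows only that the ethynyl group, which compound 4 keeps, accompanies the one number recorded. The expectation is therefore a step near zero, within the scatter, with the direction left open: a 1.2-fold lower number from compound 1 to compound 4 (0.06 log units; within the scatter) is the estimated change. Compound 4 is accordingly expected to give about 6000 nM in this assay, within a range from 1500 nM to 20000 nM.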

Compound 4, half-maximal inhibitory concentration: 30 nM
Beside the measured number, compound 4's estimate is 200-fold (2.30 log units) above it; measured number below the stated range.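

The earlier compounds shown here changed only the group that carries the ethynyl in compound 1, so they said nothing about the carbon next to the ring nitrogen. In this assay, within the data shown here, methylsulfanyl in place of methyl on that carbon gives a 230-fold lower number from compound 1 to compound 4 (2.36 log units; beyond the scatter), which makes this position far more sensitive than the earlier steps could suggest, with the ethynyl group and the rest of the structure unchanged. The data shown measure the size and direction of this step but offer nothing that accounts for it.

Among these compounds, it remains open whether the gain depends on the ethynyl group, since compound 2 and compound 3 keep methyl and differ from compound 4 in two places, so the furan-3-yl and thiophen-2-yl groups have no methylsulfanyl counterpart here. It is also unknown whether the sulfur atom itself matters or whether an amine, a methoxy group or a longer chain such as ethylsulfanyl on the same carbon would give a similar step.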